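Pyridin-2-yl to pyridin-4-yl: working notes

The compounds below may be only part of what the source reports. "The series", "measured", "known", "first", "only" and "open" are said of these compounds alone.

Among the measured compounds shown here, in a functional assay on A549 cells (Homo sapiens) for inhibition, read by MTT assay, with a stated time of 72 h (on this read-out lower numbers stand for stronger inhibition and higher numbers for weaker inhibition), two compounds have values so far. Compound 1 (`COc1ccc(-c2cc(C(=O)N3CCC4(CC3)CC(=O)c3nn(C(C)(C)C)cc3O4)c3ccccc3n2)cc1`) gives 3740 nM. Compound 2 (`CC(C)(C)n1cc2c(n1)C(=O)CC1(CCN(C(=O)c3cc(-c4ccccn4)nc4ccccc34)CC1)O2`) gives 7720 nM, the higher of the two numbers and thus the weaker inhibition of this pair.

Compound 3 (`CC(C)(C)n1cc2c(n1)C(=O)CC1(CCN(C(=O)c3cc(-c4ccncc4)nc4ccccc34)CC1)O2`) has not yet been measured. It differs from compound 2 in one group, pyridin-4-yl in place of pyridin-2-yl on an aromatic carbon, next to the ring nitrogen: pyridin-4-yl in place of pyridin-2-yl on an aromatic carbon.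

For the measured compounds named here, only one measured step bears on this change. It sits on the same carbon and is modest: a 2.1-fold higher number from compound 1 to compound 2 (0.31 log units; beyond the scatter). That step replaces 4-methoxyphenyl, so it gives only a rough scale. Going by the values given here, no measured pair compares two pyridinyl groups, and the direction is therefore poorly defined. A change no larger than that modest step is expected in this assay, most likely none beyond the scatter. The estimated step is a 1.2-fold lower number from compound 2 to compound 3 (0.07 log units; within the scatter). For compound 3 the expected value is 6500 nM, with an estimated range from 3200 nM to 13000 nM.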

Compound 3, half-maximal inhibitory concentration: 550 nM
The estimate for compound 3 lay 12-fold (1.07 log units) above the measured number; measured number below the stated range.
By their numbers in this assay, from the lowest: compound 3; then compound 1; then compound 2.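

In this assay the move of the pyridine nitrogen alone gives a 14-fold lower number from compound 2 to compound 3 (1.15 log units; beyond the scatter) and so counts for far more at this position than the earlier step suggested, although the group entering has the same heavy atoms, the same aromatic ring and the same hydrogen-bond acceptor count as the group leaving. Compared with the 4-methoxyphenyl group on the same aromatic carbon, pyridin-4-yl gives a 6.8-fold lower number from compound 1 to compound 3 (0.83 log units; beyond the scatter) while pyridin-2-yl gave the higher number, so the two pyridinyl groups fall on opposite sides of 4-methoxyphenyl and "a pyridinyl group" is no single kind of substituent at this carbon. Nothing available here accounts for the gap between the two pyridinyl groups.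

Open, going by these compounds, is where pyridin-3-yl, the remaining pyridinyl group, or an unsubstituted phenyl would fall on this scale, and so whether the low number belongs to pyridin-4-yl alone. Also open, on these data alone, is whether a methyl group, a fluorine or an amine on the pyridin-4-yl ring keeps this inhibition, and whether the same order of the three groups holds with other substituents on the shared core.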